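Saturating the side chain of compound 3

This account rests on a few compounds, and the source may have more. Where it says the series, first, only, none or still open, it means among the compounds named here.

Measured in a functional assay on A549 cells (Homo sapiens) for cytotoxicity, read by MTT assay; on this read-out higher numbers stand for weaker inhibition and lower numbers for stronger inhibition:
- compound 1 `CCOC(=O)C(C)Oc1cc(O)c2c(=O)c(O)c(-c3ccc(OC)cc3)oc2c1CC=C(C)C`: 26500 nM
- compound 2 `COc1ccc(-c2oc3c(CC=C(C)C)c(OC(C)C(=O)O)cc(O)c3c(=O)c2O)cc1`: 15300 nM
- compound 3 `COc1ccc(-c2oc3c(CC=C(C)C)c(OC/C=C/C(=O)O)cc(O)c3c(=O)c2O)cc1`: 22900 nM

The three values lie close together. Compound 3 stands within the scatter of both others: a 1.2-fold lower number from compound 1 to compound 3 (0.06 log units; within the scatter) and a 1.5-fold higher number from compound 2 to compound 3 (0.18 log units; within the scatter). The remaining step, a 1.7-fold lower number from compound 1 to compound 2 (0.24 log units; within the scatter), is also within the scatter.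

Compound 4 `COc1ccc(-c2oc3c(CC=C(C)C)c(OCCCC(=O)O)cc(O)c3c(=O)c2O)cc1` differs from compound 3 as follows: 2-carboxyethyl in place of 2-carboxyethenyl on a saturated chain carbon bound to an oxygen on an aromatic ring. Put another way, 3-carboxypropyl replaces 3-carboxyprop-2-en-1-yl. Going by the values given here, no measured step makes this exact change, but the closest, a 1.5-fold higher number from compound 2 to compound 3 (0.18 log units; within the scatter), also alters this chain and stays small. No shift beyond the scatter is therefore expected in this assay. The expected step is a 1.1-fold lower number from compound 3 to compound 4 (0.06 log units; within the scatter). For compound 4 the estimated value is 20000 nM, with an expected range of 10000 nM to 40000 nM.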

Compound 4, half-maximal inhibitory concentration: 19100 nM
Beside the measured number, compound 4's estimate is 1.0-fold (0.02 log units) above it; measured number inside the range.
By their numbers in this assay, from the lowest: compounds 2, 4, 3 and 1 (each within the scatter of the next).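

Saturating the chain gives a 1.2-fold lower number from compound 3 to compound 4 (0.08 log units; within the scatter) in this assay and so shows that the double bond of this chain can go without a shift beyond the scatter. The 3-carboxypropyl chain also stays within the scatter of the other two chains, with a 1.2-fold higher number from compound 2 to compound 4 (0.10 log units; within the scatter) and a 1.4-fold lower number from compound 1 to compound 4 (0.14 log units; within the scatter) in this assay as well, so the four chains on this oxygen cannot be told apart. Nothing measured here offers an explanation for this result.

Going by these compounds, whether an amine or an amide in place of the carboxylic acid, or a longer chain, would move the number beyond the scatter remains open.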